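The source may hold more compounds than are shown below. What is called first, only, known or untested is meant among the compounds shown, and "the series" means these compounds.

In a functional assay on UACC-257 cells (Homo sapiens) for inhibition, read by sulforhodamine B assay, with a stated time of 48 h (a higher number here means a weaker inhibitor of growth, a lower number a stronger inhibitor of growth), compound 3 `COc1ccc(-c2cc(/C=C/C(=O)c3ccc(N)cc3)[nH]n2)cc1OC` gives 6460 nM. Compound 1 `COc1cc(-c2cc(/C=C/C(=O)c3ccc(N)cc3)[nH]n2)cc(OC)c1OC` carries a single change relative to compound 3, (methoxy in place of hydrogen on an aromatic carbon), and in this assay compound 1 gives 1870 nM, a step of a 3.5-fold lower number from compound 3 to compound 1 (0.54 log units; beyond the scatter). Compound 2 `COc1ccc(C(=O)/C=C/c2cc(-c3cc(OC)c(OC)c(OC)c3)n[nH]2)cc1OC` replaces the 4-aminophenyl on the carbonyl carbon with a 3,4-dimethoxyphenyl; in this assay compound 2 gives 1490 nM, and the step is a 1.3-fold lower number from compound 1 to compound 2 (0.10 log units; within the scatter). The difference between the cores of compound 2 and compound 3 is not broken down here.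

Compound 4 `COc1cc(C(=O)/C=C/c2cc(-c3cc(OC)c(OC)c(OC)c3)n[nH]2)cc(OC)c1OC` has not yet been measured in this assay. Relative to compound 2 it carries methoxy in place of hydrogen on an aromatic carbon, the same change as that from compound 3 to compound 1, at a place described in identical words. Compound 4 is therefore expected to give 600 nM, with a likely range from 250 nM to 1500 nM. Among the measured compounds shown here, that estimate means a 2.5-fold lower number from compound 2 to compound 4 (0.40 log units; beyond the scatter), and it rests on the earlier step of a 3.5-fold lower number from compound 3 to compound 1 (0.54 log units; beyond the scatter), taken somewhat cautiously since only one such pair is measured.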

Compound 4, concentration for 50% growth inhibition: 1570 nM
Compound 4: middle estimate off by 2.6-fold (0.42 log units), on the low side; measured number above the stated range.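

In this assay, methoxy in place of hydrogen on an aromatic carbon gives a 1.1-fold higher number from compound 2 to compound 4 (0.02 log units; within the scatter), so on this core the added methoxy leaves the number within the scatter. The change therefore does not carry over from one core to the other with the size it had on the first, and the two steps differ: the same change on two cores in this assay, a 3.5-fold lower number (0.54 log units; beyond the scatter) from compound 3 to compound 1 and a 1.1-fold higher number (0.02 log units; within the scatter) from compound 2 to compound 4, 3.6-fold (0.56 log units) apart, beyond the scatter of two such steps This does not show which feature of the cores sets the two steps apart, and with a single pair on each core it gives no rule for what the same change would do on a further core.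

Still open, as far as these compounds go, is whether a hydroxyl or an ethoxy in place of the entering methoxy would give a step of its own on the core of compound 2. Also open, from the compounds shown here alone, is how a carboxylic acid or a longer chain in place of the 4-aminophenyl would read in this assay.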